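Removing the chlorine: how does cytotoxicity on Vero cells change?

A few compounds are considered here, and "the series" means these few. Any claim that something is new, unique, unknown or untested is made for them only; others in the source may bear on it.

Compound 1: `COC(=O)/C=C1\Nc2ccc(Cl)cc2OC1=O` — 1600000 nM
Compound 2: `COC(=O)/C=C1/Oc2ccccc2NC1=O` — "not determined" (no result reported)

Among the measured compounds shown here, in an ADME assay on Vero cells (Chlorocebus sabaeus) for cytotoxicity, read by MTT assay, with a stated time of 72 h (on this read-out lower numbers stand for higher toxicity in this test and higher numbers for lower toxicity in this test), compound 1 gives 1600000 nM, the only number measured here, and it points to very low toxicity. For compound 2 no result is reported in this assay. Compound 3, `COC(=O)/C=C1\Nc2ccccc2OC1=O`, differs from compound 1 by hydrogen in place of chloro on an aromatic carbon. For the measured compounds named here, with no measured step of this kind to lean on, the change is expected to stay within the usual scatter, so the step from compound 1 to compound 3, a 1.3-fold higher number from compound 1 to compound 3 (0.10 log units; within the scatter), is expected to be small and, if anything, toward lower toxicity. Compound 3 is therefore estimated at 2000000 nM, with a range of 800000 nM to 5000000 nM.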

Compound 3, half-maximal cytotoxic concentration: > 2280000 nM
Compound 3 ended at the assay's limit (the forecaster's own chance of this, stated with the estimate: 30%); middle value at least 1.1-fold (0.05 log units) from the limit.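

Replacing chloro with hydrogen on this aromatic carbon gives, in this assay, an at least 1.4-fold higher number from compound 1 to compound 3 (0.15 log units; that floor lies within the scatter). Going by these compounds, the chlorine is therefore not needed for the very low toxicity seen on these cells: without it, no sign of added toxicity appears, although the true size of the step remains unknown. The result for compound 3 is a limit of the assay, not a number: the limit of > 2280000 nM in this assay, at which 1 of the 3 values shown sits.

On these data alone, how far the step exceeds this floor stays open. Also open, as far as these compounds go, is how an amine or a carboxylic acid on this aromatic carbon would read in this assay.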